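The source may hold more compounds than are shown below. What is called first, only, known or untested is meant among the compounds shown, and "the series" means these compounds.

Measured compounds:
compound 1, `C#CCCCOC(=O)Cn1cnc2c1c(=O)n(C)c(=O)n2C`: 56800 nM
compound 2, `CCn1c(=O)ccn(C2OC(Cn3cc(COC(=O)CNC(=O)Cn4cnc5c4c(=O)n(C)c(=O)n5C)nn3)C(O)C2O)c1=O`: 3570 nM
compound 3, `Cn1c(=O)c2c(ncn2CC(=O)NCC(=O)OCc2cn(CC3OC(n4ccc(=O)[nH]c4=O)C4OC(C)(C)OC34)nn2)n(C)c1=O`: 5670 nM

All three were run in a functional assay on A549 cells (Homo sapiens) for cytotoxicity, read by MTT assay, with a stated time of 48 h; a higher number here means a weaker inhibitor, a lower number a stronger inhibitor. Compound 1 has the highest number of the three; the nearest of the other two is compound 3, whose lower value lies beyond the scatter, and the furthest is compound 2, whose still lower value also lies beyond the scatter. For the measured compounds named here, no pair of these three differs in only one place, so no single step within the measured set can be assigned to one structural change; compounds 2 and 3 are both larger conjugates that carry the core of compound 1 on a different kind of linker and ending.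

The step of interest goes from compound 1 to compound 4, `C#CCNC(=O)Cn1cnc2c1c(=O)n(C)c(=O)n2C`, which keeps the core of compound 1 and alters only the chain on the carbonyl carbon:

propargylamino in place of (pent-4-yn-1-yl)oxy on a carbonyl carbon

Compound 1 remains a weak inhibitor in this assay, and the change to compound 4 is small and leaves the core untouched. The expected step of a 1.4-fold lower number from compound 1 to compound 4 (0.15 log units; within the scatter) is therefore small, if anything toward a lower number, and may well fall within the scatter. For compound 4 the estimate is 40000 nM, with a range from 15000 nM to 120000 nM.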

Compound 4, half-maximal inhibitory concentration: 114000 nM
The estimate for compound 4 lay 2.9-fold (0.45 log units) below the measured number; measured number inside the range.
By their numbers in this assay, from the lowest: compounds 2 and 3 (each within the scatter of the next); then compounds 1 and 4 (each within the scatter of the next).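

In this assay, for the compounds shown here, propargylamino in place of (pent-4-yn-1-yl)oxy on a carbonyl carbon gives the first step that can be read at a single place (a 2.0-fold higher number from compound 1 to compound 4 (0.30 log units; within the scatter)). At this position, the exchange of the oxygen-linked chain for the nitrogen-linked one, with its amide hydrogen and a shorter chain, therefore gives no change that can be told from the scatter, and the triple bond outside aromatic rings is present on both sides of the step. No measured evidence bears on this result.

The step alters the linking atom and the chain together, so the compounds shown do not separate the two; propargyloxy or (pent-4-yn-1-yl)amino on the same carbonyl carbon would pull them apart. Also open, going by these compounds, is whether a chain without the triple bond, such as pentyl, or a carboxylic acid at this place would move the number beyond the scatter.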